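The source may hold more compounds than are shown below. What is called first, only, known or untested is meant among the compounds shown, and "the series" means these compounds.

Working notes on the series. Of the compounds shown here, three have been measured in a functional assay on A549 cells (Homo sapiens) for inhibition, read by MTT assay and WST assay, with a stated time of 72 h, tested at 10 uM; a lower number here means less inhibition of growth, a higher number more inhibition of growth at the concentration tested: compound 1 `O=C(Nc1ccc(Oc2ccc(-c3nccs3)cc2)cc1)Nc1ccc(F)c(C(F)(F)F)c1`, compound 2 `Cc1ccc(NC(=O)Nc2ccc(Oc3ccc(-c4nccs4)cc3)cc2)cc1` and compound 3 `O=C(Nc1ccc(Oc2ccc(-c3ncc[nH]3)cc2)cc1)Nc1ccc(F)c(C(F)(F)F)c1`. A fourth, compound 4 `Cc1ccc(NC(=O)Nc2ccc(Oc3ccc(-c4ncc[nH]4)cc3)cc2)cc1`, has not. In this assay compound 1 gives 76.4%. Compound 2 gives 15.6%, and compound 3 gives 63.3%.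

Two single changes branch from compound 1. The first is 4-methylphenyl in place of 4-fluoro-3-(trifluoromethyl)phenyl on an amide-type nitrogen; it made the step of a number 60.8 percentage points lower from compound 1 to compound 2 (beyond the scatter). The second is 1H-imidazol-2-yl in place of 1,3-thiazol-2-yl on an aromatic carbon; it made the step of a number 13.1 percentage points lower from compound 1 to compound 3 (beyond the scatter). Compound 3 thus stands second of the three measured numbers, nearer to compound 1 than to compound 2.

Compound 4 differs from compound 3 by 4-methylphenyl in place of 4-fluoro-3-(trifluoromethyl)phenyl on an amide-type nitrogen. For the measured compounds named here, this is the same change as the one from compound 1 to compound 2: the groups that leave and enter are identical and the place, an amide-type nitrogen whose other neighbour is a carbonyl carbon, is described in the same words. The two cores differ in the way already given for compound 3 against compound 1, a difference that on its own moved the read-out only modestly.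

Given that the one measured instance of this change is the step of a number 60.8 percentage points lower from compound 1 to compound 2 (beyond the scatter), the step from compound 3 to compound 4 is expected to be a number 57.3 percentage points lower from compound 3 to compound 4 (beyond the scatter), large and in the same direction. The wider range allows for the cores not being identical. Compound 4 is estimated at 6%, expected to lie between 0% and 25%.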

Compound 4, percent growth inhibition at one concentration: 24.6%
Beside the measured number, compound 4's estimate is 18.6 percentage points below it; measured number inside the range.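

In this assay, the change to 4-methylphenyl from 4-fluoro-3-(trifluoromethyl)phenyl on an amide-type nitrogen lowers the number again, with a number 38.7 percentage points lower from compound 3 to compound 4 (beyond the scatter), so its direction carries from one core to the other but its size does not: the same change on two cores in this assay, a number 60.8 percentage points lower (beyond the scatter) from compound 1 to compound 2 and a number 38.7 percentage points lower (beyond the scatter) from compound 3 to compound 4, 22.1 percentage points apart, beyond the scatter of two such steps

The change to 1H-imidazol-2-yl from 1,3-thiazol-2-yl, read on the compounds carrying 4-methylphenyl, gives a number 9 percentage points higher from compound 2 to compound 4 (within the scatter), so the modest loss seen with the other aryl group does not carry over either: the same change on two cores in this assay, a number 13.1 percentage points lower (beyond the scatter) from compound 1 to compound 3 and a number 9 percentage points higher (within the scatter) from compound 2 to compound 4, 22.1 percentage points apart, beyond the scatter of two such steps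

These four compounds show that the size of each step in this series depends on what stands at the other place, but they rest on a single pair of cores and show neither a cause for this dependence nor how either change would behave on a further core.

The compounds shown leave open whether the fluorine, the trifluoromethyl group or both together account for the higher numbers, as 4-fluoro-3-(trifluoromethyl)phenyl and 4-methylphenyl differ in both at once. Also open, from the compounds shown here alone, is how the series would respond to an amine or a carboxylic acid in place of the methyl group of 4-methylphenyl.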